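The source may report more compounds than this note shows. Statements on the series, on what has been measured and on what is new or still open speak of the compounds shown alone.

Working notes on the series. Among the measured compounds shown here, compound 1 `O=C1O[C@H]([C@@H](O)Cn2cc(-c3cc(F)cc(F)c3)nn2)C(OCc2ccccc2)=C1OCc1ccccc1` is the only member for which a functional assay on CFPAC-1 cells (Homo sapiens) for antiproliferative activity, read by MTT assay, with a stated time of 72 h (a lower number here means a stronger inhibitor, a higher number a weaker inhibitor), returns a number: in that assay compound 1 gives 62400 nM. Compound 2 `CCCCCc1ccc(-c2cn(C/C=C3\OC(=O)C(OCc4ccccc4)=C3OCc3ccccc3)nn2)cc1` reaches only a limit of this assay, > 100000 nM. Compound 3 `O=C1O/C(=C\Cn2cc(-c3cc(C(F)(F)F)cc(C(F)(F)F)c3)nn2)C(OCc2ccccc2)=C1OCc1ccccc1` likewise sits at a limit of this assay, > 100000 nM. For the measured compounds named here, compound 1 therefore stands alone as the one with a measured number, while compounds 2 and 3 both sit at the limit of > 100000 nM in this assay, at which 2 of the 3 values shown sit. Going by the values given here, no two measured compounds differ in a single place, so no measured step exists to set a scale for the next change.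

Compound 4 `CCCCCCCCCCc1cn(C[C@H](O)[C@H]2OC(=O)C(OCc3ccccc3)=C2OCc2ccccc2)nn1` differs from compound 1 in one place: decyl in place of 3,5-difluorophenyl on an aromatic carbon. With nothing in the measured set to anchor it, the step expected from compound 1 to compound 4 in this assay is a 1.2-fold lower number from compound 1 to compound 4 (0.10 log units; within the scatter), and no direction beyond the scatter is expected. For compound 4 the estimated value in this assay is 50000 nM, with a range from 12000 nM to 150000 nM.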

Compound 4, half-maximal inhibitory concentration: 40300 nM
The estimate for compound 4 lay 1.2-fold (0.09 log units) above the measured number, within the range that was stated.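

In this assay the series now has its first measured step, a 1.5-fold lower number from compound 1 to compound 4 (0.19 log units; within the scatter), on an aromatic carbon of the five-membered aromatic ring with 3 nitrogen. At this position, decyl, which has no ring, and 3,5-difluorophenyl, which has a six-membered aromatic ring, give values within the scatter of each other, so a ring in this group is not needed for a number to be returned in these two compounds. The remaining values are limits of the assay and not numbers: the limit of > 100000 nM in this assay, at which 2 of the 4 values shown sit.

Still open, going by these compounds, is whether an amine, a carboxylic acid or a chain longer than decyl at this position would move the value beyond the scatter. No single-place pair shown separates the hydroxyl-bearing linker of compound 1 and compound 4 from the carbon-carbon double bond linker of the other compounds.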